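Working notes: amine variation on the shared core

This account rests on a few compounds, and the source may have more. Where it says the series, first, only, none or still open, it means among the compounds named here.

Measured compounds so far:
Compound 1 `CC(=O)N1CCN(c2nc(Nc3ccc(C#N)c(C(F)(F)F)c3)nc(Oc3ccnc4ccccc34)n2)CC1`; in a functional assay on DU-145 cells (Homo sapiens) for cytotoxicity, read by sulforhodamine B assay, with a stated time of 48 h (on this read-out higher numbers stand for lower toxicity in this test and lower numbers for higher toxicity in this test), compound 1 gives > 100000 nM, a limit of the assay.
Compound 2 `N#Cc1ccc(Nc2nc(Oc3ccnc4ccccc34)nc(N3CCN(c4ccccc4)CC3)n2)cc1C(F)(F)F`; in this assay compound 2 gives > 100000 nM, likewise a limit of the assay.

For the measured compounds named here, compound 2 therefore stands at the limit of this assay, and the one further value shown is a limit too. Going by the values given here, the only measured step, a step that the two limits leave unreadable from compound 1 to compound 2, cannot be sized because of the limit of > 100000 nM in this assay, at which 2 of the 2 values shown sit.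

Compound 3 `N#Cc1ccc(Nc2nc(Oc3ccnc4ccccc34)nc(N3CCCCC3)n2)cc1C(F)(F)F` is not yet measured. Its difference from compound 2 is piperidin-1-yl in place of 4-phenylpiperazin-1-yl on an aromatic carbon. Among the compounds with values here, no measured step touches this change, and the single measured step gives no readable size, so there is nothing to anchor a direction. The expectation for compound 3 is that this assay again reports a limit rather than a number. Compound 3 is estimated at 100000 nM, with a range from 30000 nM to 300000 nM. That estimate means the step of a number no higher from compound 2 to compound 3 (the limit leaves the size open), expected to lie within the scatter.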

Compound 3, concentration lethal to 50% of the cells: > 100000 nM
Compound 3 gave a limit, no number (the forecaster's own chance of this, stated with the estimate: 70%); the middle value lies on the limit itself.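

No step among compound 1, compound 2 and compound 3 can be read, because all three stand at a limit of the assay: the limit of > 100000 nM in this assay, at which 3 of the 3 values shown sit.

The compounds shown leave open whether any amine on the shared core gives a number rather than a limit in this assay.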